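Acylation of the ring nitrogen in the shared core

The source may hold more compounds than are shown below. What is called first, only, known or untested is meant among the compounds shown, and "the series" means these compounds.

Compound 1 `O=C1NC(c2ccccc2)CN1S(=O)(=O)c1ccc2c(c1)CCCN2` carries a free hydrogen on a nitrogen on an aromatic ring in a ring of the shared core. In a functional assay on P388D1 cells (Mus musculus) for antiproliferative activity, read by MTT assay (on this read-out higher numbers stand for weaker inhibition and lower numbers for stronger inhibition), compound 1 gives 4250 nM, the highest number among the three measured compounds. Compound 2 `CCOC(=O)N1CCCc2cc(S(=O)(=O)N3CC(c4ccccc4)NC3=O)ccc21` gives 1430 nM and compound 3 `C=CCOC(=O)N1CCCc2cc(S(=O)(=O)N3CC(c4ccccc4)NC3=O)ccc21` gives 945 nM. The step of a 3.0-fold lower number from compound 1 to compound 2 (0.47 log units; beyond the scatter) and the step of a 4.5-fold lower number from compound 1 to compound 3 (0.65 log units; beyond the scatter) both lower the number beyond the scatter; the step of a 1.5-fold lower number from compound 2 to compound 3 (0.18 log units; within the scatter) stays within the scatter, so the two carbamates cannot be told apart on these numbers.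

Compound 4 `O=C(CCl)NC(=O)N1CCCc2cc(S(=O)(=O)N3CC(c4ccccc4)NC3=O)ccc21` is compound 1 with ((chloromethyl)carbonyl)carbamoyl in place of hydrogen on a nitrogen on an aromatic ring in a ring. Like the ethoxycarbonyl in compound 2 and the allyloxycarbonyl in compound 3, the entering group places a carbonyl on that nitrogen, though it also brings a hydrogen-bond donor and a chlorine, for which the series holds no comparison. The two measured steps from compound 1 bear on it; both were modest and ran in the same direction. A modest lowering of the number is therefore expected, a 3.5-fold lower number from compound 1 to compound 4 (0.55 log units; beyond the scatter), with the range widened for the untested part of the group. Compound 4 is estimated at 1200 nM, between 450 nM and 3500 nM.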

Compound 4, half-maximal inhibitory concentration: 3870 nM
Compound 4: middle estimate off by 3.2-fold (0.51 log units), on the low side; the measured number lies above the stated range.
By their numbers in this assay, from the lowest: compounds 3 and 2 (each within the scatter of the next); then compounds 4 and 1 (each within the scatter of the next).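

In this assay, a carbonyl on the nitrogen of the shared core does not by itself lower the number: the step of a 1.1-fold lower number from compound 1 to compound 4 (0.04 log units; within the scatter) stays within the scatter, so compound 4 cannot be told apart from compound 1, and compound 4 goes against the lowering seen with compound 2 and compound 3. What is attached to that carbonyl carbon therefore matters at this position, as ((chloromethyl)carbonyl)amino in place of ethoxy gives the step of a 2.7-fold higher number from compound 2 to compound 4 (0.43 log units; beyond the scatter), and in place of allyloxy gives the step of a 4.1-fold higher number from compound 3 to compound 4 (0.61 log units; beyond the scatter), both beyond the scatter. Nothing available here accounts for this difference between the two carbamates and compound 4.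

The compounds shown leave open which part of the ((chloromethyl)carbonyl)carbamoyl group goes with the loss of the carbamate step, and a plain carbamoyl, an acetylcarbamoyl without the chlorine or a simple acetyl on the same nitrogen would separate those parts. Also open is how the number responds to a longer chain on the carbamate oxygen, such as butoxy, since the two carbamates shown cannot be told apart.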